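Swapping ethoxy for sulfanyl on a nucleoside-like core

The source may report more compounds than this note shows. Statements on the series, on what has been measured and on what is new or still open speak of the compounds shown alone.

Measured in a functional assay on HEp-2 cells (Homo sapiens) for inhibition; a higher number here means that more compound is needed for the effect, a lower number that less compound is needed:
- Compound 1 `CSc1ncnc2c1nnn2[C@@H]1O[C@H](COC(C)=O)[C@@H](OC(C)=O)[C@H]1OC(C)=O`: 0.5 uM
- Compound 2 `COc1ncnc2c1nnn2[C@@H]1O[C@H](CO)[C@@H](O)[C@H]1O`: 0.3 uM
- Compound 3 `CCOc1ncnc2c1nnn2[C@@H]1O[C@H](CO)[C@@H](O)[C@H]1O`: 0.1 uM

Of these three, compound 3 has the lowest number, 0.1 uM, meaning the least compound is needed for the effect. Compound 4 `OC[C@H]1O[C@@H](n2nnc3c(S)ncnc32)[C@H](O)[C@@H]1O` is not yet measured. It differs from compound 3 as follows: sulfanyl in place of ethoxy on an aromatic carbon.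

Among the measured compounds shown here, only one measured step touches this carbon: a 3.0-fold lower number from compound 2 to compound 3 (0.48 log units; beyond the scatter). That modest step lengthens a chain on the oxygen but keeps the oxygen, so it does not show what replacing the whole group does. Compound 1 also has sulfur on this carbon and gives 0.5 uM, but it carries acetyl groups elsewhere as well, so no clean step can be read from it.

Going by compound 1 at 0.5 uM, a modest move towards a higher number is expected in this assay, though with wide uncertainty. The expected step is a 5.0-fold higher number from compound 3 to compound 4 (0.70 log units; beyond the scatter). For compound 4 the estimated value is 0.5 uM, with an expected range of 0.08 uM to 3 uM.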

Compound 4, concentration for half-maximal effect: 1 uM
Compound 4: the middle estimate sits 2.0-fold (0.30 log units) below what was measured; low and high end bracket the measured number.
By their numbers in this assay, from the lowest: compound 3; then compounds 2, 1 and 4 (each within the scatter of the next, the first and the last beyond it).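

In this assay, exchanging the whole group on this aromatic carbon can now be read directly: sulfanyl in place of ethoxy gives a 10-fold higher number from compound 3 to compound 4 (1.00 log units; beyond the scatter) on the shared core, and sulfanyl in place of methoxy gives a 3.3-fold higher number from compound 2 to compound 4 (0.52 log units; beyond the scatter) on the same core. Both steps lie beyond the scatter, so among the compounds with this otherwise unchanged core, sulfanyl needs more compound than either group that joins a chain through oxygen. Nothing available here explains these steps.

The compounds shown leave open how a propoxy group or an amine on this carbon would compare. Among the compounds shown here, it also remains open whether methylsulfanyl, seen only with the acetyl groups of compound 1, would differ from sulfanyl on the core of compound 4.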